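A few compounds are considered here, and "the series" means these few. Any claim that something is new, unique, unknown or untested is made for them only; others in the source may bear on it.

In a functional assay on HL-60 cells (Homo sapiens) for cytotoxicity, read by CCK-8 assay, with a stated time of 24 h (a higher number here means a weaker inhibitor, a lower number a stronger inhibitor), compound 3 `C=CC(=O)N1C(=O)CCSc2ccccc21` gives 44800 nM and stands lowest of the three numbers. Compound 1 `C=CC(=O)N1C(=O)CC(c2ccc(OC)cc2)Sc2ccccc21` gives 92100 nM in this assay, and compound 2 `C=CC(=O)N1C(=O)CC(c2ccc(C(F)(F)F)cc2)Sc2ccccc21` gives 106000 nM. Compound 4 `C=CC(=O)N1C(=O)CC(c2ccc(C#N)cc2)Sc2ccccc21` has not yet been measured; it differs from compound 3 by 4-cyanophenyl in place of hydrogen on a saturated ring carbon. The step that bears on it runs the other way: a 2.1-fold lower number from compound 1 to compound 3 (0.31 log units; beyond the scatter), so putting an aryl group onto that ring carbon is expected to move the number upward by a similar amount. The step of a 1.2-fold higher number from compound 1 to compound 2 (0.06 log units; within the scatter) shows that exchanging the group on the aryl ring changed little. Compound 4 is therefore expected to show a 2.1-fold higher number from compound 3 to compound 4 (0.33 log units; beyond the scatter). The estimate for compound 4 in this assay is 95000 nM, with a range from 50000 nM to 180000 nM.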

Compound 4, half-maximal inhibitory concentration: 115000 nM
Compound 4: the middle estimate sits 1.2-fold (0.08 log units) below what was measured; the measured number falls inside the stated range.
By their numbers in this assay, from the lowest: compound 3; then compounds 1, 2 and 4 (each within the scatter of the next).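

In this assay, 4-cyanophenyl in place of hydrogen on the saturated ring carbon next to the ring sulfur gives a 2.6-fold higher number from compound 3 to compound 4 (0.41 log units; beyond the scatter), making this the third aryl group at that carbon to stand beyond the scatter from compound 3. Cyano on the aryl ring gives a 1.1-fold higher number from compound 2 to compound 4 (0.04 log units; within the scatter) against trifluoromethyl and a 1.2-fold higher number from compound 1 to compound 4 (0.10 log units; within the scatter) against methoxy, so these three aryl compounds cannot be told apart. No supporting measurement accounts for these numbers. From the compounds shown here alone, whether an amine or a carboxylic acid on the aryl ring would separate from these three remains open. So does whether a methyl group on the saturated ring carbon would stay with compound 3 or with the aryl compounds.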